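Isopropoxy for acetyl on a non-cytotoxic biphenyl amide

The source may report more compounds than this note shows. Statements on the series, on what has been measured and on what is new or still open speak of the compounds shown alone.

Three compounds sharing one core have been examined in an ADME assay on HEK293 cells (Homo sapiens) for cytotoxicity, read by CellTiter-Glo and resazurin assay, with a stated time of 72 h; a lower number here means that less compound is needed, a higher number that more compound is needed for the effect. Compound 1 `CC(C)N(Cc1cccc(OCCCCCC(=O)O)c1)C(=O)c1ccccc1` carries a hydrogen on the aromatic carbon in question. In this assay compound 1 gives > 26000 nM, a limit of the assay rather than a number. Compound 2 `CC(C)N(Cc1cccc(OCCCCCC(=O)O)c1)C(=O)c1ccc(-c2cccc(-c3ccccc3)c2)cc1` adds a 3-phenylphenyl at that position. Compound 2 likewise gives > 26000 nM, which is a limit. Compound 3 `CC(=O)c1cccc(-c2ccc(C(=O)N(Cc3cccc(OCCCCCC(=O)O)c3)C(C)C)cc2)c1` carries a 3-acetylphenyl there. For compound 3 the result is > 26000 nM, again a limit and not a number. All three values therefore sit at the same limit (the limit of > 26000 nM in this assay, at which 3 of the 3 values shown sit), and the steps a step that the two limits leave unreadable from compound 1 to compound 2, a step that the two limits leave unreadable from compound 1 to compound 3 and a step that the two limits leave unreadable from compound 2 to compound 3 cannot be sized.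

Compound 4 `CC(C)Oc1cccc(-c2ccc(C(=O)N(Cc3cccc(OCCCCCC(=O)O)c3)C(C)C)cc2)c1` is the next compound, not yet measured. It differs from compound 3 by isopropoxy in place of acetyl on an aromatic carbon. Within the data shown here, no measured step is readable, so the three limits are the only evidence bearing on this change, and none of them shows any effect at all within the range of the assay. The expected step from compound 3 to compound 4 is therefore a step that the limit leaves unreadable from compound 3 to compound 4, with no direction to prefer. For compound 4 the estimate is 40000 nM, ranging from 20000 nM to 100000 nM, and a limit rather than a number is the most likely outcome.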

Compound 4, half-maximal effective concentration: > 26000 nM
Compound 4: a limit, no number; the forecaster's own chance of this, stated with the estimate: 85%; the middle value does not contradict the limit.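

In this assay compound 4 gives > 26000 nM, which is a limit and not a number. Among these compounds, no step linking compound 4 to compound 1, compound 2 or compound 3 can be read, as all four results stand at one limit: the limit of > 26000 nM in this assay, at which 4 of the 4 values shown sit. The compounds shown leave open whether any of them has a cytotoxic effect at all, and whether isopropoxy and acetyl differ in it.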